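This account rests on a few compounds, and the source may have more. Where it says the series, first, only, none or still open, it means among the compounds named here.

Working notes on the series.

Of the compounds shown here, two of the shared core have numbers so far. Compound 1 `COc1ccc(-c2cc(C(=O)Nc3ccc(Oc4ccnc5cc(OCCCN6CCCCC6)c(OC)cc45)c(F)c3)c3cc(F)ccc3n2)cc1` gives 1100 nM in a functional assay on U-87MG ATCC cells (Homo sapiens) for cytotoxicity, read by MTT assay, with a stated time of 72 h; a higher number here means a weaker inhibitor, a lower number a stronger inhibitor. Compound 2 `COc1cc2c(Oc3ccc(NC(=O)c4cc(-c5cccc(Cl)c5)nc5ccc(F)cc45)cc3F)ccnc2cc1OCCCN1CCCC1` gives 990 nM in this assay. Compound 2 holds the lower of the two numbers, but the gap to compound 1 is within the usual scatter, so the two values are read as indistinguishable and no order between them is claimed.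

The next compound, compound 3 `COc1ccc(-c2cc(C(=O)Nc3ccc(Oc4ccnc5cc(OCCCN6CCCC6)c(OC)cc45)c(F)c3)c3cc(F)ccc3n2)cc1`, has not yet been measured in this assay. Compared with compound 2 it carries 4-methoxyphenyl in place of 3-chlorophenyl on an aromatic carbon. Going by the values given here, compound 1 also carries a 4-methoxyphenyl group, and its number in this assay sits within the scatter of that of compound 2, which is the only guide available for this change.

On that basis no step beyond the scatter is expected from compound 2 to compound 3 in this assay, and the expected step is a 1.1-fold higher number from compound 2 to compound 3 (0.05 log units; within the scatter). Compound 3 is accordingly estimated at 1100 nM in this assay, with a range from 500 nM to 2500 nM.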

Compound 3, half-maximal inhibitory concentration: 930 nM
Beside the measured number, compound 3's estimate is 1.2-fold (0.07 log units) above it, within the range that was stated.
By their numbers in this assay, from the lowest: compounds 3, 2 and 1 (each within the scatter of the next).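

Both replacements can now be read directly in this assay. On the aromatic carbon next to the ring nitrogen, 4-methoxyphenyl in place of 3-chlorophenyl gives a 1.1-fold lower number from compound 2 to compound 3 (0.03 log units; within the scatter), with pyrrolidin-1-yl common to both compounds, so this single swap, which also adds a hydrogen-bond acceptor, stays within the scatter. On the saturated chain carbon, three bonds along the chain from an oxygen on an aromatic ring, pyrrolidin-1-yl in place of piperidin-1-yl gives a 1.2-fold lower number from compound 1 to compound 3 (0.07 log units; within the scatter), with 4-methoxyphenyl common to both compounds, and no supporting measurement bears on either result.

From the compounds shown here alone, each replacement rests on a single pair of compounds, so it remains open whether the same reading would hold with 3-chlorophenyl and piperidin-1-yl together, or for groups of a different kind on the aromatic carbon, such as a phenyl ring carrying a carboxylic acid. Going by these compounds, it is equally open whether a morpholin-4-yl group or an open-chain dimethylamino group at the end of the saturated chain would give a step beyond the scatter in this assay.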